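The source may hold more compounds than are shown below. What is called first, only, known or untested is meant among the compounds shown, and "the series" means these compounds.

Working notes on the series.

Compound 1 `COCCNC(=O)CCNc1ncc2c(Br)nn(-c3ccc4ncccc4c3)c2n1` carries an open-chain link between the shared core and the methoxyethyl amide. In an assay on SK-OV-3 cells for inhibition of eIF-2-alpha kinase GCN2 (Homo sapiens) (on this read-out lower numbers stand for stronger inhibition and higher numbers for weaker inhibition), compound 1 stands without a number: its entry reads "nd" (no result reported), so no result is available for it. The two measured neighbours carry a ring in that link. Compound 2 `COCCNC(=O)[C@H]1C[C@H](Nc2ncc3c(Br)nn(-c4ccc5ncccc5c4)c3n2)C1` gives 86 nM in this assay. Compound 3 `COCCNC(=O)[C@H]1CC[C@H](Nc2ncc3c(Br)nn(-c4ccc5ncccc5c4)c3n2)C1` gives 183 nM in this assay. Among the compounds with values here, the two values sit close to the edge of the usual scatter of each other, so only a modest separation between the ring sizes can be read from them, and no step between them is tabulated here.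

Compound 4 `CNS(=O)(=O)[C@@H]1CC[C@@H](Nc2ncc3c(Br)nn(-c4ccc5ncccc5c4)c3n2)C1` is the unmeasured member. It differs from compound 1 as follows: a group of 10 heavy atoms (6 carbon, 1 nitrogen, 2 oxygen, 1 sulfur; one five-membered non-aromatic ring of carbon only) in place of a group of 9 heavy atoms (6 carbon, 1 nitrogen, 2 oxygen; no ring), on a nitrogen on an aromatic ring. Within the data shown here, since compound 1 has no number, no direction or size of step can be stated for this change; the only anchor is compound 3, which shares the five-membered ring and gives 183 nM.

For compound 4 the expected value in this assay is 150 nM, with a range from 45 nM to 500 nM.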

Compound 4, half-maximal inhibitory concentration: 106 nM
Estimate against measurement, compound 4: 1.4-fold (0.15 log units) above; measured number inside the range.
By their numbers in this assay, from the lowest: compounds 2, 4 and 3 (each within the scatter of the next, the first and the last beyond it).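

No new step can be read for compound 4: in this assay its only paired partner, compound 1, has the entry "nd" (no result reported). The compounds shown leave open how the open 2-((2-methoxyethyl)carbamoyl)ethyl chain compares with the ring-bearing groups on this read-out. No supporting evidence bears on the value of compound 4.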